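The source may hold more compounds than are shown below. What is called first, only, known or untested is meant among the compounds shown, and "the series" means these compounds.

Compound 2 `CC(C)(C)Sc1c(CC(C)(C)C(=O)O)n(Cc2ccc(Cl)cc2)c2ccc(OCc3nc4ccccc4s3)cc12` gives 3 nM in a functional assay for inhibition, with Homo sapiens as the target (on this read-out lower numbers stand for stronger inhibition and higher numbers for weaker inhibition), and among the measured compounds it stands level with compound 1 `CC(C)(C)Sc1c(CC(C)(C)C(=O)O)n(Cc2ccc(Cl)cc2)c2ccc(OCc3cc4ccccc4cn3)cc12`, which gives 3 nM; the step of no change at the digits printed from compound 1 to compound 2 (within the scatter) lies within the scatter. Compound 3 `CC(C)(C)Sc1c(CC(C)(C)C(=O)O)n(Cc2ccc(Cl)cc2)c2ccc(OCc3nc4ccccc4o3)cc12` is reported in this assay only as a limit, < 7 nM, so the steps a step that the limit leaves unreadable from compound 1 to compound 3 and a step that the limit leaves unreadable from compound 2 to compound 3 cannot be sized (the limit of < 7 nM in this assay, at which 1 of the 3 values shown sits).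

Compound 4 `CC(C)c1csc(COc2ccc3c(c2)c(SC(C)(C)C)c(CC(C)(C)C(=O)O)n3Cc2ccc(Cl)cc2)n1` has not yet been measured. It differs from compound 2 by 4-isopropyl-1,3-thiazol-2-yl in place of 1,3-benzothiazol-2-yl on a saturated chain carbon bound to an oxygen on an aromatic ring. Among the compounds with values here, the only readable step, from compound 1 to compound 2, exchanged one group for another of similar size at the same place without a change beyond the scatter; the change to compound 4 removes the six-membered aromatic ring of carbon only and adds an isopropyl, which no measured step covers. The estimated step of a 1.7-fold higher number from compound 2 to compound 4 (0.22 log units; within the scatter) is therefore expected to be small, with some risk of a modest loss. Compound 4 is expected to give about 5 nM, between 2 nM and 20 nM.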

Compound 4, half-maximal inhibitory concentration: 3 nM
Compound 4: the middle estimate sits 1.7-fold (0.22 log units) above what was measured, and the stated range covers the measured number.
By their numbers in this assay, from the lowest: compounds 1, 2 and 4 (each within the scatter of the next).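

Replacing 1,3-benzothiazol-2-yl with 4-isopropyl-1,3-thiazol-2-yl, on a saturated chain carbon bound to an oxygen on an aromatic ring, removes the six-membered aromatic ring of carbon only and adds an isopropyl, and in this assay this gives no change at the digits printed from compound 2 to compound 4 (within the scatter). Against isoquinolin-3-yl, the same group gives no change at the digits printed from compound 1 to compound 4 (within the scatter), so among compounds 1, 2 and 4 a group with a single aromatic ring stands level with two groups that carry a second ring. Compound 3 is reported only as a limit, so the step from it to compound 4 cannot be read, like its other steps: the limit of < 7 nM in this assay, at which 1 of the 4 values shown sits.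

As far as these compounds go, it remains open whether this level holds with a smaller group at this place, such as an unsubstituted 1,3-thiazol-2-yl or a methyl in place of the isopropyl. Also open, from the compounds shown here alone, is how an amine or a hydroxyl on the isopropyl would read.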